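The source may hold more compounds than are shown below. What is called first, only, known or untested is meant among the compounds shown, and "the series" means these compounds.

Working notes on the series.

Compound 1 is `CCCNc1nc(C)nc2c1cnn2-c1ccccc1` and compound 2 is `CCCCNc1nc(C)nc2c1cnn2-c1ccccc1`; they share a core and differ only in the chain on the ring nitrogen. In a functional assay on G-361 cells (Homo sapiens) for cytotoxicity, read by sulforhodamine B assay (on this read-out higher numbers stand for lower toxicity in this test and lower numbers for higher toxicity in this test), compound 1 gives > 100000 nM, which is a limit of the assay rather than a number. In the same assay compound 2 gives > 100000 nM, again a limit. Within the data shown here, the step from compound 1 to compound 2 therefore reads as a step that the two limits leave unreadable from compound 1 to compound 2, and the only thing the two values show together is the limit of > 100000 nM in this assay, at which 2 of the 2 values shown sit.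

Compound 3 is `Cc1nc(Nc2ccccc2)c2cnn(-c3ccccc3)c2n1`. Against compound 1 the change is phenyl in place of propyl on a nitrogen on an aromatic ring. Among the measured compounds shown here, the single measured step bears on it only loosely, since it exchanges one chain for a longer chain on the same nitrogen and its size could not be read. Nothing measured points in either direction for a phenyl in that position. The expectation for compound 3 is therefore a step of a number no higher from compound 1 to compound 3 (the limit leaves the size open), meaning no change beyond the scatter. Compound 3 is estimated at 100000 nM, with a range from 30000 nM to 300000 nM, and it is expected that this assay may again report only a limit.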

Compound 3, concentration lethal to 50% of the cells: > 100000 nM
Compound 3 gave a limit, no number; the forecaster's own chance of this, stated with the estimate: 70%; the middle value sits exactly at the limit.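

No new step can be read among compound 1, compound 2 and compound 3, since each stands only as a limit in this assay. What the values show together is this: the limit of > 100000 nM in this assay, at which 3 of the 3 values shown sit. The compounds shown leave open whether any change on that nitrogen would give a readable number in this assay.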